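Amide substituent variation on the shared core

This account rests on a few compounds, and the source may have more. Where it says the series, first, only, none or still open, it means among the compounds named here.

Three analogues sharing one core and differing only in the group on the amide-type nitrogen have been measured in a functional assay on REH cells (Homo sapiens) for cytotoxicity, read by MTT assay, with a stated time of 72 h; on this read-out higher numbers stand for weaker inhibition and lower numbers for stronger inhibition. Compound 1 `N#Cc1ccc(NC(=O)CN2C(=O)/C(=C/c3ccc(-c4ccc(Cl)cc4)o3)SC2=S)cc1` gives 90000 nM. Compound 2 `O=C(CN1C(=O)/C(=C/c2ccc(-c3ccc(Cl)cc3)o2)SC1=S)NCc1ccc(Br)cc1` gives 75000 nM. Compound 3 `CCCCCCNC(=O)CN1C(=O)/C(=C/c2ccc(-c3ccc(Cl)cc3)o2)SC1=S` gives 55000 nM. Compound 3 carries the lowest number of the three, but the steps of a 1.4-fold lower number from compound 2 to compound 3 (0.13 log units; within the scatter) and a 1.6-fold lower number from compound 1 to compound 3 (0.21 log units; within the scatter) both sit within the scatter, so no ordering among these three can be drawn. Compound 4 `Cc1cccc(CNC(=O)CN2C(=O)/C(=C/c3ccc(-c4ccc(Cl)cc4)o3)SC2=S)c1` is the next analogue: 3-methylphenyl in place of pentyl on a saturated chain carbon bound to an amide-type nitrogen. The step that bears on this is a 1.4-fold lower number from compound 2 to compound 3 (0.13 log units; within the scatter), in which a 4-bromophenyl at the same place was exchanged for pentyl without leaving the scatter; the step of a 1.2-fold lower number from compound 1 to compound 2 (0.08 log units; within the scatter) likewise stayed within it. A 3-methylphenyl entering at that place is therefore expected to move this assay by no more than the scatter, in either direction, and the step expected is a 1.2-fold higher number from compound 3 to compound 4 (0.07 log units; within the scatter). Compound 4 is estimated at 65000 nM, with a range from 30000 nM to 140000 nM.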

Compound 4, half-maximal inhibitory concentration: 53000 nM
Compound 4: the middle estimate sits 1.2-fold (0.09 log units) above what was measured, within the range that was stated.
By their numbers in this assay, from the lowest: compounds 4, 3, 2 and 1 (each within the scatter of the next).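

With this assay as the read-out, the exchange of pentyl for 3-methylphenyl on a saturated chain carbon bound to an amide-type nitrogen gives a 1.0-fold lower number from compound 3 to compound 4 (0.02 log units; within the scatter) and so puts an aromatic ring where a ring-free chain stood without leaving the scatter. The other new steps are a 1.4-fold lower number from compound 2 to compound 4 (0.15 log units; within the scatter) and a 1.7-fold lower number from compound 1 to compound 4 (0.23 log units; within the scatter) and both also stay within the scatter, so the four amide substituents shown, whether aromatic or a plain chain, cannot be ordered. No supporting data on hand bear on why this position shows so little response.

Whether any group on the amide-type nitrogen can move this read-out beyond the scatter stays open, since an amine, a carboxylic acid or a longer chain at this place is not among the compounds shown. The four compounds also say nothing about changes elsewhere on the shared core.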